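The source may hold more compounds than are shown below. What is called first, only, known or untested is meant among the compounds shown, and "the series" means these compounds.

Measured in a functional assay on CCRF-CEM cells (Homo sapiens) for inhibition; a higher number here means a weaker inhibitor, a lower number a stronger inhibitor:
Compound 1 `C#CCN(Cc1ccc2nc(C)nc(O)c2c1)c1cccc(CC)c1`: 5000 nM
Compound 2 `C#CCN(Cc1ccc2nc(C)nc(O)c2c1)c1cccc(C(C)O)c1`: > 49000 nM

Compound 2 gives only a limit, > 49000 nM, and not a number. Compound 3 `C#CCN(Cc1ccc2nc(C)nc(O)c2c1)c1cccc(I)c1` carries iodo in place of 1-hydroxyethyl on an aromatic carbon. Going by the values given here, one measured step bears on this: an at least 9.8-fold higher number from compound 1 to compound 2 (0.99 log units; beyond the scatter), which came with hydroxy in place of hydrogen on the chain. Compound 3 has no such hydroxy, so a lower number is expected in this assay, near compound 1 at 5000 nM. The expected size of the change is an at least 12-fold lower number from compound 2 to compound 3 (1.08 log units; beyond the scatter). For compound 3 the estimated value is 4000 nM, with an expected range of 1200 nM to 15000 nM.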

Compound 3, half-maximal inhibitory concentration: > 5300 nM
Compound 3: only a limit was reported; the forecaster's own chance of this, stated with the estimate: 10%; middle value at least 1.3-fold (0.12 log units) away from the limit.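

Compound 3 gives only a limit, > 5300 nM, in this assay. Iodo in place of ethyl on this aromatic carbon comes with an at least 1.0-fold higher number from compound 1 to compound 3 (0.02 log units; that floor lies within the scatter), a floor that does not settle whether iodo reads like ethyl or much weaker. The step between compound 2 and compound 3 cannot be read, so the loss of 1-hydroxyethyl brings no measurable recovery here. From the compounds shown here alone, it remains open how an amine, a carboxylic acid or a longer chain would read on this aromatic carbon, and whether any group here gives a lower number than ethyl.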